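The source may hold more compounds than are shown below. What is called first, only, known or untested is meant among the compounds shown, and "the series" means these compounds.

Measured so far:
- compound 1 `O=C(CCc1cccc2c1B(O)OC2)Nc1cccc(-c2ccc(F)cc2)c1` gives 250 nM
- compound 2 `O=C(CCc1cccc2c1B(O)OC2)Nc1cccc(-c2ccc(OC(F)(F)F)cc2)c1` gives 640 nM

In a functional assay on MDA-MB-231 cells (Homo sapiens) for antiproliferative activity, read by MTT assay, with a stated time of 72 h (a higher number here means a weaker inhibitor, a lower number a stronger inhibitor), compound 2 reads 640 nM as the higher of the two numbers, which makes it the weaker inhibitor of the pair. Compound 3 `N#Cc1ccc(-c2cccc(NC(=O)CCc3cccc4c3B(O)OC4)c2)cc1` has not yet been measured. It keeps the rest of compound 2 and carries cyano in place of trifluoromethoxy on an aromatic carbon, para to a large group (cyano in place of trifluoromethoxy on an aromatic carbon). Among the measured compounds shown here, one measured step bears on this change, made at the same aromatic carbon. It shows a 2.6-fold higher number from compound 1 to compound 2 (0.41 log units; beyond the scatter) and is modest in size. Two compounds are thin evidence, and they give no direct reading for cyano. On that single modest step, a similarly small move is expected here, towards a lower number rather than a higher one. For the measured compounds named here, the expected change in this assay is a 1.6-fold lower number from compound 2 to compound 3 (0.20 log units; within the scatter) and no larger step is anticipated. The estimate for compound 3 is 400 nM (expected range 150 nM to 1100 nM).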

Compound 3, half-maximal inhibitory concentration: 380 nM
The estimate for compound 3 lay 1.1-fold (0.02 log units) above the measured number; low and high end bracket the measured number.
By their numbers in this assay, from the lowest: compounds 1, 3 and 2 (each within the scatter of the next, the first and the last beyond it).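

In this assay, cyano on this aromatic carbon, para to a large group, gives a 1.7-fold lower number from compound 2 to compound 3 (0.23 log units; within the scatter) against trifluoromethoxy, and against fluoro it gives a 1.5-fold higher number from compound 1 to compound 3 (0.18 log units; within the scatter). Both steps lie within the scatter, so compound 3 cannot be separated from either of the other two, even though a 2.6-fold higher number from compound 1 to compound 2 (0.41 log units; beyond the scatter) does separate those two from each other. The position therefore accepts cyano, with its 2 heavy atoms and triple bond, without a step beyond the scatter from either earlier group, and no measurement is available here that would explain the readings at this position.

Going by these compounds, whether a basic or acidic group such as an amine or a carboxylic acid on the same aromatic carbon would stay within this narrow range remains open, as does the reading with plain hydrogen there. Also open, on these data alone, is how much of the reading in this assay depends on this position at all, compared with the shared core or a longer chain in place of the one carrying the amide carbonyl.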